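Tetrazole amides: changing the acyl aryl group on two cores

This account rests on a few compounds, and the source may have more. Where it says the series, first, only, none or still open, it means among the compounds named here.

Measured so far in an assay on microsomes from liver for inhibition of sterol O-acyltransferase 1 (Rattus norvegicus); a lower number here means a stronger inhibitor, a higher number a weaker inhibitor:
compound 1 `CCCCCCCCCCCCn1nnc(C(NC(=O)c2ccccc2C(F)(F)F)c2ccccc2)n1` gives 120 nM
compound 2 `CCCCCCCCCCCCn1nnc(C(NC(=O)c2ccnc(SC)c2)c2ccccc2)n1` gives 80 nM
compound 3 `CCCCCCCCCCCCn1nnnc1C(NC(=O)c1ccccc1C(F)(F)F)c1ccccc1` gives 350 nM

Compound 1 and compound 2 share one core and differ only in the group on the carbonyl carbon: a group of 8 heavy atoms (6 carbon, 1 nitrogen, 1 sulfur; one six-membered aromatic ring with 1 hetero atom) in place of a group of 10 heavy atoms (7 carbon, 3 fluorine; one six-membered aromatic ring of carbon only), on a carbonyl carbon. In this assay this gave a 1.5-fold lower number from compound 1 to compound 2 (0.18 log units; within the scatter), so the two values are treated as alike.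

Compound 3 has the same atoms as compound 1, joined differently; the difference between the two cores is not broken down here. In this assay compound 3 stands highest of the three numbers, with compound 1 nearest and compound 2 furthest, both gaps lying beyond the scatter.

Compound 4 `CCCCCCCCCCCCn1nnnc1C(NC(=O)c1ccnc(SC)c1)c1ccccc1` is not yet measured. It is to compound 3 what compound 2 is to compound 1: a group of 8 heavy atoms (6 carbon, 1 nitrogen, 1 sulfur; one six-membered aromatic ring with 1 hetero atom) in place of a group of 10 heavy atoms (7 carbon, 3 fluorine; one six-membered aromatic ring of carbon only), on a carbonyl carbon. The place line is the same word for word in both pairs, so this is the same change on the other core. The change is seen once in measured form, and only on the core of compound 1, so how it carries to the core of compound 3 rests on a single observation.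

Among the measured compounds shown here, the expected step for compound 4 is a 1.5-fold lower number from compound 3 to compound 4 (0.16 log units; within the scatter), expected to be about as small as the only measured instance of this change, because a 1.5-fold lower number from compound 1 to compound 2 (0.18 log units; within the scatter) stayed within the scatter. For the measured compounds named here, compound 4 is therefore estimated at 240 nM in this assay, with a likely range from 110 nM to 550 nM; the wide range reflects the single precedent and the untested core.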

Compound 4, half-maximal inhibitory concentration: 140 nM
For compound 4 the middle estimate is 1.7-fold (0.23 log units) above the measured one; the measured number falls inside the stated range.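

In this assay, putting the sulfur-bearing six-membered aromatic ring with 1 hetero atom in place of 2-(trifluoromethyl)phenyl on the carbonyl carbon gave a 2.5-fold lower number from compound 3 to compound 4 (0.40 log units; beyond the scatter). This step lies beyond the scatter while the matching step on the core of compound 1 lies within it, but the gap between the two steps does not establish that the change behaves differently on the two cores: the same change on two cores in this assay, a 1.5-fold lower number (0.18 log units; within the scatter) from compound 1 to compound 2 and a 2.5-fold lower number (0.40 log units; beyond the scatter) from compound 3 to compound 4, 1.7-fold (0.22 log units) apart, within the scatter of two such steps

The result supports carrying this one change between these two cores as a working approximation, with both steps pointing the same way, but it rests on a single pair of acyl groups and two cores, and it neither fixes a precise size for the step nor shows that the same holds for any other acyl group or core.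

All four compounds keep the same dodecyl chain and the same phenyl group, so the compounds shown leave open what a shorter chain such as octyl would do on either core. Also open, going by these compounds, is whether a different acyl group, such as an unsubstituted phenyl or an aryl group carrying an amine or a carboxylic acid, would move the two cores alike in this assay.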